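Cytotoxicity of a thiazole ester series on macrophage cells

A few compounds are considered here, and "the series" means these few. Any claim that something is new, unique, unknown or untested is made for them only; others in the source may bear on it.

Compound 1: `CCOC(=O)c1sc(-c2ccccc2)nc1N1CCC(NCc2ccccc2)CC1`, 11.7%
Compound 2: `CCOC(=O)c1sc(-c2ccccc2)nc1N1CCC(NCc2ccc(F)cc2)CC1`, 6.23%
Compound 3: `CCOC(=O)c1sc(-c2ccccc2)nc1N1CCC(NCc2ccc(OCc3ccccc3)cc2)CC1`, 18.4%

In an ADME assay on RAW264.7 cells (Mus musculus) for cytotoxicity, read by MTT assay, with a stated time of 72 h, tested at 50 uM (on this read-out higher numbers stand for more inhibition at the one concentration tested (going by the name of the read-out) and lower numbers for less inhibition), compound 3 stands highest of the three numbers; the two steps leading up to it are a number 6.7 percentage points higher from compound 1 to compound 3 (within the scatter), and a number 12.2 percentage points higher from compound 2 to compound 3 (beyond the scatter). Compound 4 is `CCOC(=O)c1sc(-c2ccccc2)nc1N1CCC(NCc2ccc(C(F)(F)F)cc2)CC1`. The change from compound 3 is trifluoromethyl in place of benzyloxy on an aromatic carbon. The two steps that bear on this are the ones that brought benzyloxy in, a number 6.7 percentage points higher from compound 1 to compound 3 (within the scatter) and a number 12.2 percentage points higher from compound 2 to compound 3 (beyond the scatter); removing it is expected to undo roughly that amount, so the expected step in this assay is a modest fall, a number 8.4 percentage points lower from compound 3 to compound 4 (within the scatter). For compound 4 the expected inhibition is therefore 10%, between 2% and 20%.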

Compound 4, a percentage reported as inhibition, at one concentration (the size of the read-out at that concentration, not a potency): 22.7%
Beside the measured number, compound 4's estimate is 12.7 percentage points below it, and the stated range ends below it.
By their numbers in this assay, from the lowest: compounds 2, 1, 3 and 4 (each within the scatter of the next, the first and the last beyond it).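

In this assay, trifluoromethyl, which has no ring, takes the place of benzyloxy on this aromatic carbon with a number 4.3 percentage points higher from compound 3 to compound 4 (within the scatter) and so the ring of benzyloxy is not required for a number of this size. Trifluoromethyl is also the one group here that stands clear of both fluoro and hydrogen, with a number 16.5 percentage points higher from compound 2 to compound 4 (beyond the scatter) and a number 11 percentage points higher from compound 1 to compound 4 (beyond the scatter) while benzyloxy stands clear of fluoro alone. No evidence on the origin of these steps is available. The compounds shown leave open how an amine or a carboxylic acid at this place would read, and whether a methoxy group would fall with fluoro or with trifluoromethyl.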